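The source may report more compounds than this note shows. Statements on the series, on what has been measured and on what is new or still open speak of the compounds shown alone.

Of the compounds shown here, three have so far been measured in a functional assay on MCF7 cells (Homo sapiens) for inhibition, read by sulforhodamine B assay, with a stated time of 48 h; on this read-out lower numbers stand for stronger inhibition of growth and higher numbers for weaker inhibition of growth. Compound 1 `COc1ccc(/C=C/c2cc(=O)cco2)cc1OC` gives 954 uM in this assay. Compound 2 `COc1ccc(/C=C/C2CC=CC(=O)O2)cc1` gives 25.5 uM, and compound 3 `COc1ccc(/C=C/C2CC=CC(=O)O2)cc1OC` gives 7.8 uM. Compound 3 thus stands lowest of the three numbers: the nearest to it is compound 2, and the furthest is compound 1, whose number lies far higher. Among the measured compounds shown here, the one step between measured compounds that differ in a single place is a 3.3-fold lower number from compound 2 to compound 3 (0.51 log units; beyond the scatter), a modest change that lies beyond the scatter.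

Compound 4 `COc1cc(/C=C/C2CC=CC(=O)O2)cc(OC)c1OC` differs from compound 3 by methoxy in place of hydrogen on an aromatic carbon. For the measured compounds named here, the only measured step that bears on this change is a 3.3-fold lower number from compound 2 to compound 3 (0.51 log units; beyond the scatter), since it too consisted of a methoxy in place of hydrogen on an aromatic carbon. Compound 4 is therefore expected to show a small further lowering in this assay, or none beyond the scatter, because the earlier step of a 3.3-fold lower number from compound 2 to compound 3 (0.51 log units; beyond the scatter) was itself only modest and there is nothing to say that a third methoxy repeats it. The step that this expectation means is a 1.6-fold lower number from compound 3 to compound 4 (0.19 log units; within the scatter). Compound 4 is accordingly estimated at 5 uM, with a range from 1.5 uM to 20 uM.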

Compound 4, concentration for growth inhibition (reported as GI): 15.3 uM
Compound 4: the middle estimate sits 3.1-fold (0.49 log units) below what was measured, and the stated range covers the measured number.
By their numbers in this assay, from the lowest: compounds 3, 4 and 2 (each within the scatter of the next, the first and the last beyond it); then compound 1.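

In this assay the methoxy that enters compound 4 sits on an aromatic carbon of a six-membered aromatic ring of carbon only, ortho to a methoxy group, meta to a second methoxy group and meta to a group of 9 heavy atoms, and this replacement gives a 2.0-fold higher number from compound 3 to compound 4 (0.29 log units; within the scatter) and so separates the two compounds by no more than repeated measurements would. The same replacement at the earlier position gave a 3.3-fold lower number from compound 2 to compound 3 (0.51 log units; beyond the scatter) and that step stood clear of the scatter, so among these compounds a methoxy in place of hydrogen does not act alike at every aromatic carbon, and the earlier lowering is not repeated at this position. Nothing shown here explains why the two steps differ.

The compounds shown leave open whether a different group at this position, such as a hydroxyl, a fluorine or an amine, would separate from compound 3 in this assay where the methoxy does not. They also leave open what a longer chain, such as an ethoxy in place of one of the methoxy groups, would do on the same ring.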